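Isopropyl to (oxan-4-yl)methyl on the aromatic nitrogen

The source may report more compounds than this note shows. Statements on the series, on what has been measured and on what is new or still open speak of the compounds shown alone.

Three compounds of the series carry numbers in a functional assay on MKN-45 cells (Homo sapiens) for antiproliferative activity, with a stated time of 72 h; a lower number here means a stronger inhibitor, a higher number a weaker inhibitor. Compound 1 `Cn1cc(-c2ccc(NC(=O)c3cn(CC4CCOCC4)cc(-c4ccc(F)cc4F)c3=O)cc2)c2c(N)ncnc21` gives 501 nM. Compound 2 `Cn1cc(-c2ccc(NC(=O)c3cn(CC4CCOCC4)cc(-c4ccc(F)cc4)c3=O)c(F)c2)c2c(N)ncnc21` gives 210 nM. Compound 3 `CC(C)n1cc(C(=O)Nc2cc(F)c(-c3c[nH]c4ncnc(N)c34)cc2F)c(=O)c(-c2ccc(F)cc2)c1` gives 13.2 nM, the lowest of the three; its nearest neighbour is compound 2, and compound 1 stands furthest from it, both gaps beyond the scatter.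

Compound 4 `Nc1ncnc2[nH]cc(-c3cc(F)c(NC(=O)c4cn(CC5CCOCC5)cc(-c5ccc(F)cc5)c4=O)cc3F)c12` has not yet been measured. It differs from compound 3 in one place: (oxan-4-yl)methyl in place of isopropyl on an aromatic nitrogen. Among the compounds with values here, no pair of measured compounds differs in this one place alone, so no measured step shows what the change does. Within the data shown here, compounds 1 and 2 carry the (oxan-4-yl)methyl group on a core that is otherwise not the same as that of compound 3, so their values show only that this group is compatible with measurable activity.

Among the measured compounds shown here, the expectation for compound 4 is a step of a 1.5-fold higher number from compound 3 to compound 4 (0.18 log units; within the scatter) from compound 3, which is within the scatter, because compound 3 gives 13.2 nM and no measured step separates the two groups. Compound 4 is therefore estimated at 20 nM, with a range from 6 nM to 70 nM.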

Compound 4, half-maximal inhibitory concentration: 29.8 nM
The estimate for compound 4 lay 1.5-fold (0.17 log units) below the measured number, within the range that was stated.
By their numbers in this assay, from the lowest: compound 3; then compound 4; then compound 2; then compound 1.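

In this assay, within the data shown here, the change from isopropyl to (oxan-4-yl)methyl on the aromatic nitrogen gives a 2.3-fold higher number from compound 3 to compound 4 (0.35 log units; beyond the scatter) and provides the first measured step at this position. The step is modest: with the larger group, which adds a six-membered non-aromatic ring and a hydrogen-bond acceptor, compound 4 still gives 29.8 nM. No measurement shown here accounts for the size of this step.

Still open, on these data alone, is how the number would move with cyclohexylmethyl, which keeps a six-membered ring without the ring oxygen, with a 2-methoxyethyl chain, or with piperidin-4-ylmethyl, which carries an amine. Also open is whether the same change would give a similar step on the cores of compound 1 and compound 2, where no isopropyl counterpart is shown.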